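The compounds below may be only part of what the source reports. "The series", "measured", "known", "first", "only" and "open" are said of these compounds alone.

In a functional assay on Caco-2 cells (Homo sapiens) for inhibition, read by MTT assay, with a stated time of 48 h (a lower number here means a stronger inhibitor, a higher number a weaker inhibitor), compound 1 `COc1cc(/C=N/Nc2nc(-c3cccc(Br)c3)cs2)cc(Br)c1OC` gives 43400 nM. Compound 3 `COc1cc(/C=N/Nc2nc(-c3ccc(C(F)(F)F)cc3)cs2)cc(Br)c1OC` gives 65900 nM, which lies within the usual scatter of compound 1, so these two numbers cannot be ranked. Compound 2 `COc1cc(/C=N/Nc2nc(-c3cccc(Br)c3)cs2)c(Br)c(Br)c1OC` yields only a limit, > 100000 nM, and not a true number.

Compound 4 `COc1ccccc1-c1csc(N/N=C/c2cc(Br)c(OC)c(OC)c2)n1` keeps the rest of compound 1 and changes one group: 2-methoxyphenyl in place of 3-bromophenyl on an aromatic carbon. In words, 2-methoxyphenyl stands in place of 3-bromophenyl on an aromatic carbon of the five-membered ring. Going by the values given here, the only measured step is an at least 2.3-fold higher number from compound 1 to compound 2 (0.36 log units; beyond the scatter), a bromo in place of hydrogen on an aromatic carbon. That step leaves the 3-bromophenyl group untouched, so it says little about this swap.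

The closer guide is compound 3 at 65900 nM, whose number stays near that of compound 1 at 43400 nM. No step beyond the scatter is therefore expected in this assay, and the expected change is a 1.2-fold higher number from compound 1 to compound 4 (0.06 log units; within the scatter). A reading at the limit of the assay remains possible. For compound 4 the estimated value is 50000 nM, with an expected range from 20000 nM to 100000 nM.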

Compound 4, half-maximal inhibitory concentration: > 100000 nM
Compound 4 was reported as a limit; the forecaster's own chance of this, stated with the estimate: 20%; middle value at least 2.0-fold (0.30 log units) from the limit.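

In this assay, swapping 3-bromophenyl for 2-methoxyphenyl gives an at least 2.3-fold higher number from compound 1 to compound 4 (0.36 log units; beyond the scatter), which shows that the group on this carbon of the five-membered ring can matter. The earlier compounds shown here could not show this: compound 1 gives 43400 nM and compound 3, changed at the same carbon, gives 65900 nM, two numbers that cannot be ranked. The value of compound 4, > 100000 nM, is a limit of the assay and not a number, so the true size of this change stays unknown, and the same ceiling also applies elsewhere among these compounds: the limit of > 100000 nM in this assay, at which 2 of the 4 values shown sit.

Compound 4 removes the bromo and brings in the methoxy at a different place on the phenyl ring, all in one change, and the compounds shown cannot separate these parts from one another. They also leave open how this carbon would respond to a phenyl ring carrying an amine or a carboxylic acid, or to a group with no aromatic ring at all, such as a longer chain.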